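A methyl added to the thiophene carbonyl of compound 2

The source may hold more compounds than are shown below. What is called first, only, known or untested is meant among the compounds shown, and "the series" means these compounds.

Compound 2 `CCNC(=O)[C@H]1O[C@@H](n2cnc3c(NNC(=O)c4cccs4)nc(Cl)nc32)[C@H](O)[C@@H]1O` carries a (thiophen-2-yl)carbonyl group on the shared core. In an assay on CHO cells for displacement of a labelled ligand from adenosine receptor A3 (Homo sapiens) (on this read-out lower numbers stand for stronger inhibition and higher numbers for weaker inhibition), compound 2 gives only a limit, > 5000 nM. Its neighbour compound 1 `CCNC(=O)[C@H]1O[C@@H](n2cnc3c(NNC(=O)c4ccccc4)nc(Cl)nc32)[C@H](O)[C@@H]1O` bears a phenyl on the same carbonyl carbon. In this assay compound 1 likewise gives only a limit, > 5000 nM. The step that the two limits leave unreadable from compound 1 to compound 2 cannot be sized because of the limit of > 5000 nM in this assay, at which 2 of the 2 values shown sit.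

Compound 3 `CCNC(=O)[C@H]1O[C@@H](n2cnc3c(NNC(=O)c4sccc4C)nc(Cl)nc32)[C@H](O)[C@@H]1O` differs from compound 2 by methyl in place of hydrogen on an aromatic carbon, turning thiophen-2-yl into 3-methylthiophen-2-yl. The only measured step that bears on this change is a step that the two limits leave unreadable from compound 1 to compound 2, and since its size is not readable, it gives no direction for this assay; both measured values sit at the same limit, and no shown step is known to lie beyond the scatter. Compound 3 is therefore expected to give 9000 nM in this assay, between 3000 nM and 40000 nM, most probably reported again only as a limit. The step that the limit leaves unreadable from compound 2 to compound 3 that this estimate means is expected to stay within the scatter.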

Compound 3, inhibition constant: > 5000 nM
Compound 3 gave a limit, no number; the forecaster's own chance of this, stated with the estimate: 80%; the middle value does not contradict the limit.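

The steps from compound 1 and from compound 2 to compound 3 cannot be read, because all three compounds give only a limit, with no number: the limit of > 5000 nM in this assay, at which 3 of the 3 values shown sit. The compounds shown leave open whether phenyl, thiophen-2-yl and 3-methylthiophen-2-yl on the carbonyl carbon differ at all in this assay.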